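This account rests on a few compounds, and the source may have more. Where it says the series, first, only, none or still open, it means among the compounds named here.

Compound 1 `COc1cc([C@](O)(CCN(C)C)[C@@H](c2cc3cc(Br)ccc3nc2OC)c2ccnc(OC)c2OC)cc(OC(C)C)n1`, compound 2 `COc1cc([C@](O)(CCN(C)C)[C@@H](c2cc3cc(Br)ccc3nc2OC)c2cccc(OC)c2F)cc(SC)n1` and compound 3 `COc1cc([C@](O)(CCN(C)C)[C@@H](c2cc3cc(C#N)ccc3nc2OC)c2cccc(OC)c2F)cc(SC)n1` share a common core and were examined in an ADME assay on microsomes from liver (Mus musculus) for metabolic stability; on this read-out lower numbers stand for slow clearance and higher numbers for fast clearance. Compound 1 gives 6.7 uL/min, compound 2 gives 20 uL/min and compound 3 gives 36 uL/min. Going by the values given here, compound 1 thus gives a clearly lower number than compound 3, while compound 2 and compound 3 lie within the scatter of each other, so the one measured step, a 1.8-fold higher number from compound 2 to compound 3 (0.26 log units; within the scatter), says little on its own. Compound 4 `COc1cccc([C@H](c2cc3cc(C#N)ccc3nc2OC)[C@@](O)(CCN(C)C)c2cc(SC)nc(SC)c2)c1F` has not yet been measured in this assay . It differs from compound 3 in one place: methylsulfanyl in place of methoxy on an aromatic carbon. Among the compounds with values here, no measured step covers this kind of change: the step of a 1.8-fold higher number from compound 2 to compound 3 (0.26 log units; within the scatter) concerns a different position, and compound 1 and compound 2 differ from compound 3 at several places at once, so their numbers cannot be tied to the methylsulfanyl group alone. Within the data shown here, with no directly comparable step, the expected number for compound 4 lies close to the value of compound 3, with wide uncertainty. The estimate for compound 4 is 45 uL/min, with a range from 20 uL/min to 100 uL/min. That estimate amounts to an expected step of a 1.3-fold higher number from compound 3 to compound 4 (0.10 log units; within the scatter).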

Compound 4, intrinsic clearance in a liver preparation (reported as CLH), per the amount of preparation that the assay uses: 20 uL/min
Estimate against measurement, compound 4: 2.3-fold (0.35 log units) above; low and high end bracket the measured number.
By their numbers in this assay, from the lowest: compound 1; then compounds 2, 4 and 3 (each within the scatter of the next).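

In this assay, putting methylsulfanyl in place of methoxy on the aromatic carbon next to the ring nitrogen gives a 1.8-fold lower number from compound 3 to compound 4 (0.26 log units; within the scatter), which lies within the scatter, so the two compounds cannot be told apart on this read-out. Going by these compounds alone, this is the first measured step at this place on the six-membered aromatic ring with 1 nitrogen, and it shows that swapping the oxygen of methoxy for the sulfur of methylsulfanyl, with the same count of heavy atoms and hydrogen-bond acceptors, produces no clear shift in the clearance number on the shared core. Nothing measured here gives a reason for this outcome.

A single pair cannot show whether the same swap would read the same way with bromo in place of cyano elsewhere on the core. From the compounds shown here alone, whether a different group at this place, such as ethoxy, an amine or a carboxylic acid, would move the number beyond the scatter stays open, and so does what the other methylsulfanyl group on the same ring contributes to the read-out.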